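The source may report more compounds than this note shows. Statements on the series, on what has been measured and on what is new or still open speak of the compounds shown alone.

Measured compounds, displacement of the labelled ligand:

compound 1 `COc1ccccc1N1CCN(C(=O)CCc2c(-c3ccc(Cl)cc3)[nH]c3ccccc23)CC1`: 31 nM
compound 2 `COc1ccccc1N1CCN(C(=O)CCc2c(-c3ccc(Cl)cc3)[nH]c3cc(Cl)ccc23)CC1`: 4.9 nM
compound 3 `CC(=O)c1ccc2c(c1)c(CCC(=O)N1CCC(O)(Cc3ccccc3)CC1)c(-c1ccc(Cl)cc1)n2C`: 0.19 nM

In an assay on CHO cells for displacement of a labelled ligand from Substance-P receptor (Homo sapiens) (a lower number here means a stronger inhibitor, a higher number a weaker inhibitor), compound 3 gives the lowest number of the three; its distance to compound 2 and to compound 1 lies beyond the scatter in both cases, so compound 3 is the most potent of the measured set.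

Within the data shown here, the only single-site step measured so far is a 6.3-fold lower number from compound 1 to compound 2 (0.80 log units; beyond the scatter), a chloro in place of hydrogen on an aromatic carbon of the shared core. It shows that substitution on that ring of the core is tolerated and can help, but it says nothing about the nature of a larger substituent there.

Compound 4 `Cn1c(-c2ccc(Cl)cc2)c(CCC(=O)N2CCC(O)(Cc3ccccc3)CC2)c2cc(-c3ccncc3)ccc21` differs from compound 3 by pyridin-4-yl in place of acetyl on an aromatic carbon. Among the measured compounds shown here, no measured pair covers this kind of exchange, so the expectation rests only on the tolerance seen in this assay for substitution on that ring. A step of about a 2.6-fold higher number from compound 3 to compound 4 (0.42 log units; beyond the scatter) is estimated, with the risk of some loss from the larger group. Compound 4 is therefore expected to give 0.5 nM, within a range of 0.1 nM to 3 nM.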

Compound 4, half-maximal inhibitory concentration: 5.5 nM
For compound 4 the middle estimate is 11-fold (1.04 log units) below the measured one; measured number outside the range, above it.
By their numbers in this assay, from the lowest: compound 3; then compounds 2 and 4 (each within the scatter of the next); then compound 1.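

At this position, meta to a fused ring and para to a fused ring, the exchange of one group for another matters in this assay: pyridin-4-yl in place of acetyl gives a 29-fold higher number from compound 3 to compound 4 (1.46 log units; beyond the scatter). Among these compounds, the earlier chloro step showed only that adding a small group to the shared core can be accepted, whereas this step shows that the acetyl of compound 3 cannot be replaced by a six-membered aromatic ring without a large change in the number. No measurement at hand bears on why the step is this large.

Still open, from the compounds shown here alone, is whether the step comes from the loss of acetyl or from the entry of pyridin-4-yl. A phenyl or a carboxamide on this same carbon would bear on that question.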